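Series notes: replacing the terminal phenyl in compound 3

A few compounds are considered here, and "the series" means these few. Any claim that something is new, unique, unknown or untested is made for them only; others in the source may bear on it.

Of the compounds shown here, three have been measured in an assay on isolated protein for inhibition of Myeloperoxidase (Homo sapiens), with a stated time of 10 min; on this read-out lower numbers stand for stronger inhibition and higher numbers for weaker inhibition. Compound 1 `Nc1cc(C2CCNCCc3cccc(c3)OCc3cccc(c3)Cn3cc2cn3)c2nn[nH]c2n1` gives 17 nM in this assay. Compound 2 `Nc1cc(Cc2ccn(-c3cccc(-c4ccccc4)c3)n2)c2nn[nH]c2n1` gives 85 nM in this assay. Compound 3 `Nc1cc(Cc2ccn(Cc3cccc(-c4ccccc4)c3)n2)c2nn[nH]c2n1` gives 55 nM in this assay. On these three numbers compound 3 stands second highest: its nearest neighbour is compound 2, whose number is higher by an amount within the scatter, so the two are not ordered against each other; its furthest is compound 1, whose number is lower by an amount beyond the scatter.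

Compound 4 `Nc1cc(Cc2ccn(Cc3cccc(Oc4cccc5c4CNC5)c3)n2)c2nn[nH]c2n1` is not yet measured. It differs from compound 3 in one place: a group of 10 heavy atoms (8 carbon, 1 nitrogen, 1 oxygen; one five-membered non-aromatic ring with 1 hetero atom, one six-membered aromatic ring of carbon only) in place of a group of 6 heavy atoms (6 carbon; one six-membered aromatic ring of carbon only), on an aromatic carbon The entering group is the larger of the two and brings one hydrogen-bond donor and two hydrogen-bond acceptors where the phenyl brought none; it sits meta to a large group.

Going by the values given here, no measured pair in the set shows a change of this kind, so no step is available to lean on, and only the structural change itself and the values of compounds 1, 2 and 3 inform the expectation. The step from compound 3 to compound 4 is expected to be small, a 1.4-fold lower number from compound 3 to compound 4 (0.14 log units; within the scatter), most likely within the scatter and, if anything, towards a lower number. Compound 4 is estimated at 40 nM in this assay, within a range from 12 nM to 130 nM.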

Compound 4, half-maximal inhibitory concentration: 26 nM
Compound 4: the middle estimate sits 1.5-fold (0.19 log units) above what was measured; the range from low to high includes it.
By their numbers in this assay, from the lowest: compounds 1 and 4 (each within the scatter of the next); then compounds 3 and 2 (each within the scatter of the next).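

In this assay, going by these compounds alone, the exchange of phenyl for the larger group on this aromatic carbon, meta to a large group, gives a 2.1-fold lower number from compound 3 to compound 4 (0.33 log units; beyond the scatter), the first step at this position, modest in size but beyond the scatter. The position therefore accepts a group with more heavy atoms, a five-membered non-aromatic ring and one hydrogen-bond donor with two hydrogen-bond acceptors, and inhibition is not lost; the number moves down rather than up. This single step changes several features at once, so it cannot assign the shift to any one of them, and no measurement at hand explains the shift.

Going by these compounds, whether the lower number depends on the oxygen linking the two parts of the entering group or on the nitrogen in its non-aromatic ring remains open, and a plain phenoxy group or an aminomethyl group at the same carbon would help to separate the two. On these data alone, it also remains open whether the same exchange would carry over to compound 2, which has the same terminal phenyl.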